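Oxazolyl nucleoside series: chain extension and cytotoxicity

The compounds below may be only part of what the source reports. "The series", "measured", "known", "first", "only" and "open" are said of these compounds alone.

Within the data shown here, the three measured members share one core and differ mainly in the group carried on the five-membered aromatic ring and in the sugar acylation. Compound 1 `CCCCc1ccc(-c2cc(-c3cn([C@H]4C[C@H](OC(C)=O)[C@@H](COC(C)=O)O4)c(=O)[nH]c3=O)on2)cc1` carries a 4-butylphenyl group and gives in an ADME assay on MT4 cells (Homo sapiens) for cytotoxicity (on this read-out lower numbers stand for higher toxicity in this test and higher numbers for lower toxicity in this test), a value of 3000 nM. Compound 2 `CCCCCCCCc1cc(-c2cn([C@H]3C[C@H](O)[C@@H](CO)O3)c(=O)[nH]c2=O)on1`, with an octyl chain and a free sugar, gives in this assay 3000 nM. Compound 3 `CC(=O)OC[C@H]1O[C@@H](n2cc(-c3cc(C)no3)c(=O)[nH]c2=O)C[C@@H]1OC(C)=O`, with a methyl group and the diacetylated sugar, gives in this assay 3000 nM, level with compounds 1 and 2 within the scatter. Among the measured compounds shown here, the one single-point step, no change at the digits printed from compound 1 to compound 3 (within the scatter), shows no change within the scatter, so exchanging a large aryl group for methyl left the read-out where it was.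

Compound 4 `CCCc1cc(-c2cn([C@H]3C[C@H](OC(C)=O)[C@@H](COC(C)=O)O3)c(=O)[nH]c2=O)on1` is the next candidate. Relative to compound 3 the change is ethyl in place of hydrogen on a saturated chain carbon bound to an aromatic carbon. For the measured compounds named here, no measured step bears on this change directly; the closest, the step from compound 1 to compound 3, was flat, and compound 2 with its longer chain also sits at the same level. Accordingly no movement beyond the scatter is expected in this assay, and the step from compound 3 to compound 4 is estimated as no change at the digits printed from compound 3 to compound 4 (within the scatter). For compound 4 the expected value in this assay is 3000 nM, with a range of 1500 nM to 6000 nM.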

Compound 4, half-maximal cytotoxic concentration: 3000 nM
For compound 4 middle estimate and measured number coincide at the digits printed, within the range that was stated.
By their numbers in this assay, from the lowest: compounds 1, 2, 3 and 4 (each within the scatter of the next).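

The group on the aromatic carbon of the diacetylated series now reads flat in this assay for a third kind of substituent: extending methyl to propyl gives no change at the digits printed from compound 3 to compound 4 (within the scatter), and exchanging 4-butylphenyl for propyl gives no change at the digits printed from compound 1 to compound 4 (within the scatter). Compound 1 and compound 3 showed only an aryl group and a methyl at this place, whereas compound 4 adds a short saturated chain, and ethyl entering on the saturated chain carbon bound to an aromatic carbon leaves the read-out where it stood. No supporting measurement bears on this flat result.

On these data alone, all four compounds sit at the same printed value, so it remains open whether an amine or a carboxylic acid at the end of the chain, or an octyl chain on the diacetylated sugar, would shift this read-out. Compound 2 differs from compound 4 in both the chain and the sugar acylation, so the shown compounds do not separate any contribution of the free sugar from that of the chain.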